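Exchanging the group on the carbonyl of compound 1

This account rests on a few compounds, and the source may have more. Where it says the series, first, only, none or still open, it means among the compounds named here.

Of the compounds shown here, three have been measured so far in a functional assay on 786-0 cells (Homo sapiens) for antiproliferative activity, read by sulforhodamine B assay, with a stated time of 48 h (on this read-out higher numbers stand for weaker inhibition of growth and lower numbers for stronger inhibition of growth), and they give a first frame of reference. Compound 1 (`CCCCCC[C@@H](O)C/C=C\CCCCCCCC(=O)N[C@@H](C)c1ccccc1`) gives 6.7 ug/mL in this test, and compound 2 (`CCCCCCCC/C=C\CCCCCCCC(=O)N1CCCC1`) gives 5.2 ug/mL in the same test, a gap within the usual scatter of repeated measurements. Compound 3 (`CCCCC/C=C\C/C=C\CCCCCCCC(=O)N1CCCCC1`) gives 58.4 ug/mL as a clearly higher number, so compound 1 sits well under compound 3 and level with compound 2.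

The next compound, compound 4 (`CCCCCC[C@@H](O)C/C=C\CCCCCCCC(=O)N1CCOCC1`), has not yet been measured. It carries morpholin-4-yl in place of (1-phenylethyl)amino on a carbonyl carbon. The six-membered aromatic ring of carbon only is lost, and so is the amide hydrogen.

Going by the values given here, no two measured compounds differ in just one place, so this exchange has no direct precedent. Compound 2 at 5.2 ug/mL and compound 3 at 58.4 ug/mL both lack the amide hydrogen, but their chains differ from that of compound 1, so they offer only a loose guide. The expected change is a 2.2-fold higher number from compound 1 to compound 4 (0.35 log units; beyond the scatter) and it points to a higher number, meaning weaker inhibition of growth. For compound 4 the estimated value in this assay is 15 ug/mL with 5 ug/mL to 50 ug/mL as the expected range.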

Compound 4, concentration for 50% growth inhibition: 36 ug/mL
Compound 4: middle estimate off by 2.4-fold (0.38 log units), on the low side; measured number inside the range.
By their numbers in this assay, from the lowest: compounds 2 and 1 (each within the scatter of the next); then compounds 4 and 3 (each within the scatter of the next).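

In this assay, going by these compounds alone, this is the first comparison in which only the group on the carbonyl carbon changes while the rest of the molecule stays the same, and the result is a 5.4-fold higher number from compound 1 to compound 4 (0.73 log units; beyond the scatter). Morpholin-4-yl in place of (1-phenylethyl)amino therefore gives weaker inhibition of growth, a step beyond the scatter, which shows that the choice of group at this place matters on a shared chain, something the earlier compounds could not show with their differing chains. The exchange removes the six-membered aromatic ring of carbon only and the amide hydrogen and adds a ring oxygen all at once, and no measurement shown here bears on why the number rises.

Within the data shown here, the single step leaves open which of these differences goes with the weaker inhibition. A cyclohexylamino group would keep the amide hydrogen without the aromatic ring, while N-methyl-(1-phenylethyl)amino would keep the aromatic ring without the amide hydrogen, and piperidin-1-yl on the same chain would differ from morpholin-4-yl only in the ring oxygen.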